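A few compounds are considered here, and "the series" means these few. Any claim that something is new, unique, unknown or untested is made for them only; others in the source may bear on it.

Measured so far in a functional assay on MDA-MB-231 cells (Homo sapiens) for antiproliferative activity; a higher number here means a weaker inhibitor of growth, a lower number a stronger inhibitor of growth:
compound 1 `O=C(NC1CC1)c1ccc(-c2cnn3c(NCC4CCOCC4)nc(Oc4ccccc4)nc23)cc1` — 350 nM
compound 2 `CC(=O)Nc1cccc(Oc2nc(NCC3CCOCC3)n3ncc(-c4ccc(C(=O)NC5CC5)c(C)c4)c3n2)c1` — 1600 nM

Compound 2 has the higher of the two numbers; compound 1 sits lower, and the gap between them is beyond the usual scatter. Compound 3 `Cc1cc(-c2cnn3c(NCC4CCOCC4)nc(Nc4ccccc4F)nc23)ccc1C(=O)NC1CC1` differs from compound 2 by (2-fluorophenyl)amino in place of 3-acetamidophenoxy on an aromatic carbon. Within the data shown here, no measured pair shows this change on its own, so the size of the step is open. The expectation is a move toward lower numbers, of the order of the gap between compound 2 and compound 1, given as a 3.2-fold lower number from compound 2 to compound 3 (0.51 log units; beyond the scatter). Compound 3 is therefore estimated at 500 nM, within a range of 150 nM to 1600 nM.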

Compound 3, concentration for 50% growth inhibition: 47 nM
Estimate against measurement, compound 3: 11-fold (1.03 log units) above, and the stated range ends above it.
By their numbers in this assay, from the lowest: compound 3; then compound 1; then compound 2.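

In this assay the position between two ring nitrogen atoms is sensitive, with (2-fluorophenyl)amino in place of 3-acetamidophenoxy giving a 34-fold lower number from compound 2 to compound 3 (1.53 log units; beyond the scatter) as a large step on an otherwise unchanged structure. Among these compounds, this is the first pair differing in one place, so a change at this position can now be read on its own. No data shown bear on why the step is this large.

As far as these compounds go, the change replaces the linking atom and the ring substituents together, so their shares remain open. A 2-fluorophenoxy or 3-acetamidophenylamino group at this position would separate them.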